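The compounds below may be only part of what the source reports. "The series", "measured", "known", "first", "only" and "open" are said of these compounds alone.

Measured in a functional assay (aorta) with Oryctolagus cuniculus as the target; on this read-out lower numbers stand for tighter binding and higher numbers for weaker binding:
- compound 1 `COc1cc(C(=O)O)ccc1OCCCN1CCC(C(c2ccc(F)cc2)c2ccc(F)cc2)CC1`: 79.4 nM
- compound 2 `Fc1ccc(C(c2ccc(F)cc2)C2CCN(CCCOc3ccccc3)CC2)cc1`: 1.59 nM

Of these two, compound 2 has the lower number, at 1.59 nM. Compound 3 `Fc1ccc(C(c2ccc(F)cc2)C2CCN(CCCSc3ccccc3)CC2)cc1` departs from compound 2 in one place: phenylsulfanyl in place of phenoxy on a saturated chain carbon, three bonds along the chain from an amine nitrogen in a ring. In words, this is phenylsulfanyl in place of phenoxy on a saturated chain carbon, three bonds along the chain from an amine nitrogen in a ring.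

Among the compounds with values here, the only measured step, a 50-fold lower number from compound 1 to compound 2 (1.70 log units; beyond the scatter), is large, but it bears only loosely on this change. It replaces the group on the oxygen and keeps the oxygen itself, so no measurement tests the new exchange. From the compounds shown here alone, a step beyond the scatter is therefore not expected, and the direction remains open. The expected step is a 1.3-fold higher number from compound 2 to compound 3 (0.10 log units; within the scatter). In this assay, the estimated value for compound 3 is 2 nM, with an expected range of 0.6 nM to 7 nM.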

Compound 3, dissociation constant: 3.16 nM
The estimate for compound 3 lay 1.6-fold (0.20 log units) below the measured number; the measured number falls inside the stated range.
By their numbers in this assay, from the lowest: compounds 2 and 3 (each within the scatter of the next); then compound 1.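

In this assay, phenylsulfanyl in place of phenoxy on a saturated chain carbon, three bonds along the chain from an amine nitrogen in a ring, gives a 2.0-fold higher number from compound 2 to compound 3 (0.30 log units; within the scatter), so oxygen and sulfur cannot be told apart at this place on this read-out. The large separation from compound 1 also holds with phenylsulfanyl, at a 25-fold lower number from compound 1 to compound 3 (1.40 log units; beyond the scatter), as it did with phenoxy. Nothing available accounts for either step.

The compounds shown leave open how a sulfone, a secondary amine or a plain methylene would read in place of the oxygen or sulfur, and whether a longer chain would carry phenylsulfanyl equally well. They also do not separate the carboxylic acid of compound 1 from its methoxy group.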